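This account rests on a few compounds, and the source may have more. Where it says the series, first, only, none or still open, it means among the compounds named here.

Measured in a functional assay on DU-145 cells (Homo sapiens) for inhibition, read by trypan blue exclusion, with a stated time of 96 h; a lower number here means a stronger inhibitor of growth, a higher number a weaker inhibitor of growth:
Compound 1 `O=C(/C(=C\c1ccc(O)c([N+](=O)[O-])c1)SCc1ccc(Cl)cc1)c1ccc(Cl)cc1`: 10000 nM
Compound 2 `COc1ccccc1/C=C(/SCc1ccc(Cl)cc1)C(=O)c1ccc(Cl)cc1`: 1000 nM
Compound 3 `Cc1ccc(C)c(/C=C(/SCc2ccc(Cl)cc2)C(=O)c2ccc(Cl)cc2)c1`: 10000 nM

Compound 3 shares the highest of these three numbers with compound 1, and the comparison shows no change at the digits printed from compound 1 to compound 3 (within the scatter). Only compound 2 stands apart, as seen in a 10-fold lower number from compound 1 to compound 2 (1.00 log units; beyond the scatter) and again in a 10-fold higher number from compound 2 to compound 3 (1.00 log units; beyond the scatter).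

The next compound is compound 4 `CSc1ccc(/C=C(/SCc2ccc(Cl)cc2)C(=O)c2ccc(Cl)cc2)cc1`. It keeps the rest of compound 3 and carries 4-(methylsulfanyl)phenyl in place of 2,5-dimethylphenyl on a double-bonded chain carbon bound to a double-bonded chain carbon. All three measured steps exchange the group at this same place, on a double-bonded chain carbon bound to a double-bonded chain carbon, so all three bear on the question. Two of them were modest and one showed no change. Within the data shown here, none of the measured compounds carries the incoming group, so the data cannot show directly what it does.

Compound 3 already sits at the top of the measured range, and compound 2 at 1000 nM shows that a lower number is possible with an exchange here. A small downward move is therefore expected, close to the scatter: a 2.0-fold lower number from compound 3 to compound 4 (0.30 log units; within the scatter). For compound 4 the estimated value is 5000 nM, with an expected range from 1000 nM to 15000 nM.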

Compound 4, concentration for 50% growth inhibition: 25000 nM
Compound 4: the middle estimate sits 5.0-fold (0.70 log units) below what was measured, and the stated range ends below it.
By their numbers in this assay, from the lowest: compound 2; then compounds 1 and 3 (each within the scatter of the next); then compound 4.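

In this assay, the exchange to 4-(methylsulfanyl)phenyl gives a 2.5-fold higher number from compound 3 to compound 4 (0.40 log units; beyond the scatter) and also a 2.5-fold higher number from compound 1 to compound 4 (0.40 log units; beyond the scatter), so the level shared by compound 1 and compound 3 is not the upper end for this place: a change on this double-bonded chain carbon can also weaken growth inhibition. Among these compounds, with a 25-fold higher number from compound 2 to compound 4 (1.40 log units; beyond the scatter) as well, compound 4 is the weakest inhibitor of growth of the four, and the span across this one place is now wider than the earlier compounds showed. The 2,5-dimethylphenyl and 4-(methylsulfanyl)phenyl groups have the same heavy-atom count and the same kind of ring, so the number moves here even though those counts stay the same.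

The compounds shown leave open what a phenyl group carrying an amine or a carboxylic acid would do at this place, and whether 2-methoxyphenyl would keep its lower number if the rest of the shared core were changed. Nothing given here accounts for the higher number seen with 4-(methylsulfanyl)phenyl.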